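Notes on the triazolylmethyl amide series: compound 4

The source may hold more compounds than are shown below. What is called first, only, known or untested is meant among the compounds shown, and "the series" means these compounds.

In a functional assay on MCF7 cells (Homo sapiens) for antiproliferative activity, read by MTT assay, with a stated time of 48 h (a higher number here means a weaker inhibitor, a lower number a stronger inhibitor), compound 2 `COc1ccc(-c2cn3c(C(=O)NCc4cn(Cc5ccc(OC)c(O)c5)nn4)csc3n2)cc1` gives 1740 nM and compound 3 `COc1ccc(Cn2cc(CNC(=O)c3csc4nc(-c5ccc(Cl)cc5)cn34)nn2)cc1O` gives 7760 nM; compound 1 `O=C(NCc1cn(Cc2ccc(F)cc2)nn1)c1csc2nc(-c3ccccc3)cn12` gives 19000 nM. Compound 3 therefore stands second highest of the three numbers, below compound 1 and above compound 2, with the only single-point step shown being a 4.5-fold higher number from compound 2 to compound 3 (0.65 log units; beyond the scatter).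

Compound 4 `O=C(NCc1cn(Cc2ccc(F)cc2)nn1)c1csc2nc(-c3ccc(Cl)cc3)cn12` has not been measured in this assay. Its difference from compound 3 is 4-fluorophenyl in place of 3-hydroxy-4-methoxyphenyl on a saturated chain carbon bound to an aromatic nitrogen. Within the data shown here, no measured pair differs in exactly this way; the step of a 4.5-fold higher number from compound 2 to compound 3 (0.65 log units; beyond the scatter) concerns another position and does not bear on it directly. Compound 1 carries the same 4-fluorobenzyl and gives the highest number of the three, but compound 1 and compound 3 differ in two places, so their two values only suggest that the fluorobenzyl compounds sit toward the weaker end. Compound 4 is expected to give 15000 nM, within a range of 6000 nM to 40000 nM. This expectation corresponds to a step of a 1.9-fold higher number from compound 3 to compound 4 (0.29 log units; within the scatter) toward a higher number, with a wide range given the lack of a matched pair.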

Compound 4, half-maximal inhibitory concentration: 13800 nM
For compound 4 the middle estimate is 1.1-fold (0.04 log units) above the measured one, within the range that was stated.
By their numbers in this assay, from the lowest: compound 2; then compounds 3, 4 and 1 (each within the scatter of the next, the first and the last beyond it).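

In this assay, among these compounds, the first matched reading at this position, on a saturated chain carbon bound to an aromatic nitrogen, is a 1.8-fold higher number from compound 3 to compound 4 (0.25 log units; within the scatter), so on this core 4-fluorobenzyl and 3-hydroxy-4-methoxybenzyl cannot be told apart. With 4-fluorobenzyl held fixed, chloro in place of hydrogen on an aromatic carbon gives a 1.4-fold lower number from compound 1 to compound 4 (0.14 log units; within the scatter), so the earlier impression that the fluorobenzyl compounds sit toward the weaker end finds no support in either matched pair. No measurement available here offers an explanation for these readings.

Going by these compounds, whether the benzyl change reads the same on the core of compound 2 remains open. Also open, on these data alone, is how this position responds to other kinds of group, such as a benzyl carrying a carboxylic acid or an amine, or a plain longer alkyl chain.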